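A pyrrole-bearing group on compound 1

The compounds below may be only part of what the source reports. "The series", "measured", "known", "first", "only" and "open" are said of these compounds alone.

Values in a functional assay on P388 cells (Mus musculus) for cytotoxicity; a higher number here means a weaker inhibitor, a lower number a stronger inhibitor:
compound 1 `Cc1cc(-c2c(F)cc3c(=O)ccn(C4CC4)c3c2F)cc(C)n1`: 15000 nM
compound 2 `COc1ccc(Cc2cn(C3CC3)c3c(F)c(-c4cc(C)nc(C)c4)c(F)cc3c2=O)cc1`: 21000 nM
compound 3 `Cc1cc(-c2c(F)cc3c(=O)c(Cc4ccccc4O)cn(C4CC4)c3c2F)cc(C)n1`: 670 nM

Compound 1 sits level with compound 2 at the weak end of this small set, and compound 3 lies well below both. Compound 4 `Cc1cc(-c2c(F)cc3c(=O)c(Cc4ccc[nH]4)cn(C4CC4)c3c2F)cc(C)n1` keeps the core of compound 1 and differs in one place: (1H-pyrrol-2-yl)methyl in place of hydrogen on an aromatic carbon. Two measured steps make the same kind of replacement at that place. Putting in 4-methoxybenzyl gave a 1.4-fold higher number from compound 1 to compound 2 (0.15 log units; within the scatter), while putting in 2-hydroxybenzyl gave a 22-fold lower number from compound 1 to compound 3 (1.35 log units; beyond the scatter). Comparing those two groups directly gives a 31-fold lower number from compound 2 to compound 3 (1.50 log units; beyond the scatter). Neither group holds a five-membered aromatic ring, so these steps are only a loose guide. The new group holds a hydrogen-bond donor, as does the hydroxy group of compound 3 at 670 nM, so a lower number in this assay is expected, though probably not as low. The estimated step is a 6.0-fold lower number from compound 1 to compound 4 (0.78 log units; beyond the scatter). Compound 4 is expected at about 2500 nM, with an estimated range of 600 nM to 10000 nM.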

Compound 4, half-maximal inhibitory concentration: 930 nM
Estimate against measurement, compound 4: 2.7-fold (0.43 log units) above; low and high end bracket the measured number.
By their numbers in this assay, from the lowest: compounds 3 and 4 (each within the scatter of the next); then compounds 1 and 2 (each within the scatter of the next).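

In this assay, the large gain at this place is not tied to the 2-hydroxybenzyl group of compound 3, since (1H-pyrrol-2-yl)methyl gives a 16-fold lower number from compound 1 to compound 4 (1.21 log units; beyond the scatter). Exchanging 2-hydroxyphenyl for 1H-pyrrol-2-yl gives a 1.4-fold higher number from compound 3 to compound 4 (0.14 log units; within the scatter), so a five-membered aromatic ring serves as well here as the six-membered ring with its hydroxy group. Exchanging 4-methoxyphenyl for the same pyrrole gives a 23-fold lower number from compound 2 to compound 4 (1.35 log units; beyond the scatter), which shows that the two groups carrying a hydrogen-bond donor sit together, apart from the 4-methoxybenzyl group, which carries none.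

No measurement shown explains these steps. As far as these compounds go, whether the donor itself matters stays open: 2-methoxybenzyl or (1-methylpyrrol-2-yl)methyl at this place would separate the donor from the ring that carries it.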